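A few compounds are considered here, and "the series" means these few. Any claim that something is new, unique, unknown or untested is made for them only; others in the source may bear on it.

Working notes on the series.

Compound 3 `CCC1(Cc2ccccc2)OS(=O)(=O)C=C1NCc1ccccc1` stands at a limit of this kind of measurement rather than at a number: in an ADME assay on HEL cells (Homo sapiens) for cytotoxicity, with a stated time of 3 days (a higher number here means that more compound is tolerated, a lower number that less compound is tolerated), compound 3 gives >= 80000 nM, a limit. Of the three values in hand, two sit at this same limit (the limit of >= 80000 nM in this assay, at which 2 of the 3 values shown sit). Compound 1 `CCC1(Cc2ccccc2)OS(=O)(=O)C=C1OCc1ccc([N+](=O)[O-])cc1` also gives only a limit here, >= 80000 nM. Compound 2 `CCC1(Cc2ccccc2)OS(=O)(=O)C=C1OCc1ccc(OC)cc1` gives a limit as well, >= 200000 nM, the one at which a single value sits (the limit of >= 200000 nM in this assay, at which 1 of the 3 values shown sits). Among the compounds with values here, the one step between measured neighbours, a step that the two limits leave unreadable from compound 1 to compound 2, is therefore not readable in size, so none of the measured steps gives a usable size for what follows.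

Compound 4 `CCC1(Cc2ccccc2)OS(=O)(=O)C=C1OCC1CCCCC1` differs from compound 3 by cyclohexylmethoxy in place of benzylamino on a double-bonded ring carbon. Within the data shown here, no measured step covers this kind of exchange. Among the measured compounds shown here, with every value so far at a limit, the step from compound 3 to compound 4 is expected to be a step that the limit leaves unreadable from compound 3 to compound 4, nothing beyond the scatter. Compound 4 is therefore expected to give about 100000 nM, in a range from 40000 nM to 300000 nM, most likely reported again as a limit.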

Compound 4, minimum cytotoxic concentration: >= 200000 nM
Compound 4 ended at the assay's limit (the forecaster's own chance of this, stated with the estimate: 80%); middle value at least 2.0-fold (0.30 log units) from the limit.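

No size can be read for the steps linking compound 4 to compound 1, compound 2 or compound 3, since all four values are limits. The compounds shown leave open where any of them would reach a measured cytotoxic concentration in this assay, and whether these exchanges change it.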